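Fluoro Added to a Dinitro Oxindole Core

The source may report more compounds than this note shows. Statements on the series, on what has been measured and on what is new or still open speak of the compounds shown alone.

The series rests on a shared core in which an oxindole carries two indole substituents, and it is read in a functional assay on A549 cells (Homo sapiens) for cytotoxicity, read by MTT assay, with a stated time of 48 h; a higher number here means a weaker inhibitor, a lower number a stronger inhibitor. Compound 1, `O=C1Nc2ccccc2C1(c1c[nH]c2ccc([N+](=O)[O-])cc12)c1c[nH]c2ccc([N+](=O)[O-])cc12`, carries a nitro group on each indole; in this assay compound 1 gives 10300 nM. Compound 2, `O=C1Nc2ccc(F)cc2C1(c1c[nH]c2ccccc12)c1c[nH]c2ccccc12`, has unsubstituted indoles and a fluoro on the oxindole; in this assay compound 2 gives 12700 nM. Compound 3, `COc1cccc2[nH]cc(C3(c4c[nH]c5cccc(OC)c45)C(=O)Nc4ccc(F)cc43)c12`, has methoxy on each indole and the same fluoro; in this assay compound 3 gives 7800 nM. The number for compound 1 sits within the usual scatter of both compound 2 and compound 3, so the three measured compounds cannot be told apart in this assay.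

Compound 4, `O=C1Nc2ccc(F)cc2C1(c1c[nH]c2ccc([N+](=O)[O-])cc12)c1c[nH]c2ccc([N+](=O)[O-])cc12`, keeps the two nitro groups of compound 1 and differs from it in one place: fluoro in place of hydrogen on an aromatic carbon. Among the compounds with values here, no measured pair shows this change on its own. Compound 2 and compound 3 both carry the fluoro and give numbers within the scatter of compound 1, so the expected step in this assay from compound 1 to compound 4 is none beyond the scatter, a 1.1-fold higher number from compound 1 to compound 4 (0.03 log units; within the scatter). For compound 4 the estimate in this assay is 11000 nM, within a range from 5000 nM to 25000 nM.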

Compound 4, half-maximal inhibitory concentration: 7700 nM
Compound 4: the middle estimate sits 1.4-fold (0.15 log units) above what was measured; low and high end bracket the measured number.
By their numbers in this assay, from the lowest: compounds 4, 3, 1 and 2 (each within the scatter of the next).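

Within the data shown here, compound 1 and compound 4 form the first pair that isolates this change on the shared core, and in this assay the step is a 1.3-fold lower number from compound 1 to compound 4 (0.13 log units; within the scatter), with both nitro groups held constant. Fluoro in place of hydrogen on this aromatic carbon, which lies on a six-membered aromatic ring of carbon only within a fused system of two rings, therefore gives no change that can be told from the scatter in this nitro-bearing pair, something the earlier fluoro compounds, compound 2 and compound 3, could not show without a partner lacking only the fluoro. No supporting data bear on why the number holds here, so the result remains an observation from a single pair.

The compounds shown leave open whether the same replacement would give a similarly small step with unsubstituted or methoxy-bearing indoles, as neither compound 2 nor compound 3 has a partner lacking only the fluoro. They also leave open whether a different group at this position, such as an amine or a carboxylic acid, would move the number beyond the scatter.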